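Methyl in Place of Bromo on the Aryl Ring

The compounds below may be only part of what the source reports. "The series", "measured", "known", "first", "only" and "open" are said of these compounds alone.

Measured so far in a functional assay on Hep cells (Homo sapiens) for cytotoxicity, read by sulforhodamine B assay, with a stated time of 48 h; on this read-out lower numbers stand for stronger inhibition and higher numbers for weaker inhibition:
Compound 1, `CC1=C(/C=C/C(=O)/C=C/c2ccc(Cl)cc2)C(C)(C)CCC1`, gives 90600 nM.
Compound 2, `CC1=C(/C=C/C(=O)/C=C/c2ccccc2[N+](=O)[O-])C(C)(C)CCC1`, gives 44900 nM.
Compound 3, `CC1=C(/C=C/C(=O)/C=C/c2ccccc2Br)C(C)(C)CCC1`, gives 16300 nM.

All three share the same core and differ only in the aryl ring at the far end of the chain. Compound 3 stands lowest of the three numbers, and both steps leading to it lie beyond the usual scatter: a 5.6-fold lower number from compound 1 to compound 3 (0.74 log units; beyond the scatter) and a 2.8-fold lower number from compound 2 to compound 3 (0.44 log units; beyond the scatter). On these numbers compound 3 is the strongest of the three in this assay.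

Compound 4, `CC1=C(/C=C/C(=O)/C=C/c2ccccc2C)C(C)(C)CCC1`, differs from compound 3 in one place: methyl in place of bromo on an aromatic carbon. Going by the values given here, no measured step swaps a bromo for a methyl, so no direct precedent exists. Among the compounds with values here, the two steps that bear on it show only that changing the group on the aryl ring shifts the number by modest amounts, in either direction. A change of similar size, or one within the scatter, is therefore expected here, with a slight lean toward a higher number.

Compound 4 is estimated at 25000 nM, with a likely range from 10000 nM to 60000 nM. This estimate means an expected step of a 1.5-fold higher number from compound 3 to compound 4 (0.19 log units; within the scatter), close to the scatter.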

Compound 4, half-maximal inhibitory concentration: 41000 nM
Beside the measured number, compound 4's estimate is 1.6-fold (0.21 log units) below it; low and high end bracket the measured number.
By their numbers in this assay, from the lowest: compound 3; then compounds 4, 2 and 1 (each within the scatter of the next, the first and the last beyond it).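

At this place on the ring, ortho to a large group, bromo and methyl are not interchangeable in this assay: both groups count as a single heavy atom with no hydrogen-bond donors or acceptors, yet the swap gives a 2.5-fold higher number from compound 3 to compound 4 (0.40 log units; beyond the scatter) and so moves the number beyond the usual scatter. Methyl and nitro at the same place cannot be told apart, with a 1.1-fold lower number from compound 2 to compound 4 (0.04 log units; within the scatter) as the step between them, which leaves the bromo of compound 3 alone at the strong end of this set and compound 4 level with compound 2. The comparison with the remaining compound gives a 2.2-fold lower number from compound 1 to compound 4 (0.34 log units; beyond the scatter) as its step, but 2-methylphenyl replaces 4-chlorophenyl there, so the group and its place on the ring change together and neither can be credited alone.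

Nothing available here explains why the bromo compound gives the lowest number. Still open, on these data alone, is how other groups at this place would compare with bromo, such as an amine, a carboxylic acid, a methoxy or an iodo, and whether any would give a lower number than compound 3.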